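Thiophene to benzofuran swap on two related cores

A few compounds are considered here, and "the series" means these few. Any claim that something is new, unique, unknown or untested is made for them only; others in the source may bear on it.

Working notes on a four-compound set. Compound 1 `Nc1nc2c(c(-c3cccs3)cn2[C@@H]2O[C@H](CO)[C@@H](O)[C@H]2O)c(=O)[nH]1` carries a thiophen-2-yl group; compound 3 `Nc1nc2c(c(-c3cc4ccccc4o3)cn2[C@@H]2O[C@H](CO)[C@@H](O)[C@H]2O)c(=O)[nH]1` carries 1-benzofuran-2-yl in its place (1-benzofuran-2-yl in place of thiophen-2-yl on an aromatic carbon). Compound 2 `CN(C)c1ncnc2c1c(-c1cccs1)cn2[C@@H]1O[C@H](CO)[C@@H](O)[C@H]1O` carries the thiophen-2-yl group on a second core; how that core differs from the core of compound 1 is not broken down here. Compound 4 `CN(C)c1ncnc2c1c(-c1cc3ccccc3o1)cn2[C@@H]1O[C@H](CO)[C@@H](O)[C@H]1O`, not yet measured, carries 1-benzofuran-2-yl on the core of compound 2 (1-benzofuran-2-yl in place of thiophen-2-yl on an aromatic carbon). The place of this change reads word for word as in the pair of compound 1 and compound 3, so it is the same change made on the second core.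

In a functional assay on HCT-116 cells (Homo sapiens), read by MTT assay, with a stated time of 72 h (on this read-out higher numbers stand for weaker inhibition and lower numbers for stronger inhibition), compound 1 gives only a limit, > 20000 nM. Compound 2 likewise gives only a limit, > 20000 nM. Compound 3 gives only a limit, > 100000 nM. The step that the two limits leave unreadable from compound 1 to compound 3 therefore cannot be sized. Two of the three values sit at the limit of > 20000 nM in this assay, at which 2 of the 3 values shown sit. One value sits at the limit of > 100000 nM in this assay, at which 1 of the 3 values shown sits.

For compound 4 the expectation rests on compound 2 sitting at a limit and on the unreadable step from compound 1 to compound 3. The step that the limit leaves unreadable from compound 2 to compound 4 is expected to be essentially flat, with a real number unlikely to appear. Compound 4 is estimated at 40000 nM, within a range from 15000 nM to 150000 nM.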

Compound 4, half-maximal inhibitory concentration: > 20000 nM
Compound 4: only a limit was reported; the forecaster's own chance of this, stated with the estimate: 85%; the middle value is on the limit's open side.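

In this assay compound 4 gives > 20000 nM, which is a limit of the assay and not a number. Compound 2 also stands only as a limit, so no new step can be read between compound 2 and compound 4. The compounds shown leave open whether 1-benzofuran-2-yl in place of thiophen-2-yl changes the read-out on either core, and what real value any of the four compounds has.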